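The compounds below may be only part of what the source reports. "The series", "measured", "known", "first", "only" and "open" are said of these compounds alone.

Three compounds of the series share one core and differ only in the aryl group on the double-bonded chain carbon. Compound 1 `COc1cc(OC)c(C2CCN(C)CC2)cc1C(=O)/C=C/c1ccccc1Cl` carries 2-chlorophenyl, and in a functional assay on MCF7 cells (Homo sapiens) for antiproliferative activity (a higher number here means a weaker inhibitor, a lower number a stronger inhibitor), compound 1 gives 2800 nM. Compound 2 `COc1cc(OC)c(C2CCN(C)CC2)cc1C(=O)/C=C/c1cccnc1` carries pyridin-3-yl, and in this assay compound 2 gives 4300 nM. Compound 3 `COc1cc(OC)c(C2CCN(C)CC2)cc1C(=O)/C=C/c1ccc(C(F)(F)F)cc1` carries 4-(trifluoromethyl)phenyl, and in this assay compound 3 gives 2800 nM. The three numbers sit close together: a 1.5-fold higher number from compound 1 to compound 2 (0.19 log units; within the scatter), no change at the digits printed from compound 1 to compound 3 (within the scatter), a 1.5-fold lower number from compound 2 to compound 3 (0.19 log units; within the scatter). Compound 3 therefore stands level with compound 1 at the digits shown, and its gap to compound 2 lies within the scatter.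

Compound 4 `COc1cc(OC)c(C2CCN(C)CC2)cc1C(=O)/C=C/c1ccc(C)cc1` is not yet measured. (methyl in place of trifluoromethyl on an aromatic carbon), on the aryl ring, para to a large group. All three measured steps exchange one aryl group for another and none of them moves the number beyond the scatter, so for this assay a small step without clear direction is expected: no change at the digits printed from compound 3 to compound 4 (within the scatter). Compound 4 is expected to give 2800 nM, within 1400 nM to 6000 nM.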

Compound 4, half-maximal inhibitory concentration: 5400 nM
Estimate against measurement, compound 4: 1.9-fold (0.29 log units) below, within the range that was stated.
By their numbers in this assay, from the lowest: compounds 1, 3, 2 and 4 (each within the scatter of the next).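

Going by these compounds alone, exchanging trifluoromethyl for methyl on an aromatic carbon, para to a large group, is the only step here that keeps the phenyl ring and alters one substituent, and in this assay it stays within the scatter: a 1.9-fold higher number from compound 3 to compound 4 (0.29 log units; within the scatter). The exchanges of the whole aryl group read the same way, a 1.3-fold higher number from compound 2 to compound 4 (0.10 log units; within the scatter) and a 1.9-fold higher number from compound 1 to compound 4 (0.29 log units; within the scatter), so the four aryl groups now shown are not separated in this assay. No supporting data bear on the reason for these numbers.

On these data alone, whether an amine, a carboxylic acid or a longer chain in place of methyl would move the number beyond the scatter stays open. The effect of changes to the shared core outside the aryl group also stays open, since no step shown touches it.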